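Swapping chloro for methoxy on the aromatic ring

The source may hold more compounds than are shown below. What is called first, only, known or untested is meant among the compounds shown, and "the series" means these compounds.

Of the compounds shown here, three sharing one core have been measured in a functional assay, read by spectrophotometry, with a stated time of 2 h, tested at 0.5 mg/mL; on this read-out higher numbers stand for a stronger effect at the one concentration tested and lower numbers for a weaker effect. Compound 1 `CC(C)[C@@H]1CC[C@@H](C)C[C@@]12N(C)C(=O)[C@@H]1[C@H]3C(=O)NC(=O)[C@H]3ON12` gives 23.5%. Compound 2 `CC(C)[C@@H]1CC[C@@H](C)C[C@@]12N(C)C(=O)[C@@H]1[C@H]3C(=O)N(C)C(=O)[C@H]3ON12` gives 39.2%, which is a number 15.7 percentage points higher from compound 1 to compound 2 (beyond the scatter). Compound 3 `CC(C)[C@@H]1CC[C@@H](C)C[C@@]12N(C)C(=O)[C@@H]1[C@H]3C(=O)N(c4ccc(Cl)cc4)C(=O)[C@H]3ON12` gives 29.7%, a number that lies within the usual scatter of both compound 1 and compound 2, as the steps of a number 6.2 percentage points higher from compound 1 to compound 3 (within the scatter) and a number 9.5 percentage points lower from compound 2 to compound 3 (within the scatter) show.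

Compound 4 `COc1ccc(N2C(=O)[C@H]3[C@H](ON4[C@@H]3C(=O)N(C)[C@@]43C[C@H](C)CC[C@H]3C(C)C)C2=O)cc1` differs from compound 3 in one place: methoxy in place of chloro on an aromatic carbon. Within the data shown here, no measured pair shows this exact exchange. The two steps that touch the same aromatic group, from compound 1 and from compound 2 to compound 3, both stayed within the scatter, so the aromatic substituent has so far made little difference in this assay. A change on that ring is therefore expected to produce no step beyond the scatter. The expected step is a number 0.3 percentage points higher from compound 3 to compound 4 (within the scatter). Compound 4 is expected to give 30%, with a likely range from 18% to 42%.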

Compound 4, a percentage reported as activity, at one concentration (the size of the read-out at that concentration, not a potency): 48.9%
For compound 4 the middle estimate is 18.9 percentage points below the measured one; measured number above the stated range.
By their numbers in this assay, from the lowest: compounds 1, 3, 2 and 4 (each within the scatter of the next, the first and the last beyond it).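

In this assay, among these compounds, the group carried on the aromatic ring matters after all: methoxy in place of chloro gives a number 19.2 percentage points higher from compound 3 to compound 4 (beyond the scatter) even though the rest of the molecule is unchanged, a difference the earlier steps on this nitrogen gave no sign of. The 4-methoxyphenyl group also separates clearly from the plain amide hydrogen, with a number 25.4 percentage points higher from compound 1 to compound 4 (beyond the scatter) as its step, but a number 9.7 percentage points higher from compound 2 to compound 4 (within the scatter) leaves it unresolved from methyl, so an aromatic ring here does not outperform the small group in this data. Nothing measured in this set explains why methoxy and chloro differ.

With only chloro and methoxy shown on this ring, it remains open how a hydroxyl, an amine or a longer ether such as ethoxy at the same place would read. From the compounds shown here alone, whether the same exchange would hold at other concentrations also remains open, since each number comes from a single concentration.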